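The source may report more compounds than this note shows. Statements on the series, on what has been measured and on what is new or still open speak of the compounds shown alone.

Measured so far:
- Compound 1 `Cc1cccc(NC(=O)c2nn(C)c(-c3ccc(F)cc3)c2C)n1`: 1.1 nM
- Compound 2 `Cc1c(C(=O)Nc2ccc(Cl)cn2)nn(C)c1-c1ccc(F)cc1`: 184 nM

In a functional assay on HEK293 cells for negative allosteric modulation of metabotropic glutamate receptor 5 (Homo sapiens), read by FLIPR and calcium flux (on this read-out lower numbers stand for stronger inhibition and higher numbers for weaker inhibition), compound 2 gives the higher of the two numbers, weaker than compound 1 by a 170-fold higher number from compound 1 to compound 2 (2.22 log units; beyond the scatter). Compound 3 `Cc1c(C(=O)Nc2ccncc2)nn(C)c1-c1ccc(F)cc1` differs from compound 2 by pyridin-4-yl in place of 5-chloropyridin-2-yl on an amide-type nitrogen, again a change on the pyridine ring carried by the amide. Going by the values given here, the one measured step, a 170-fold higher number from compound 1 to compound 2 (2.22 log units; beyond the scatter), shows that such changes on this ring can move the number a long way, so a large step is expected here too, most likely toward weaker inhibition. Compound 3 is therefore estimated at 2000 nM (range 300 nM to 12000 nM), a step of an 11-fold higher number from compound 2 to compound 3 (1.04 log units; beyond the scatter).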

Compound 3, half-maximal inhibitory concentration: 301 nM
Compound 3: the middle estimate sits 6.6-fold (0.82 log units) above what was measured; measured number inside the range.
By their numbers in this assay, from the lowest: compound 1; then compounds 2 and 3 (each within the scatter of the next).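

On the amide-type nitrogen, pyridin-4-yl and 5-chloropyridin-2-yl cannot be told apart (a 1.6-fold higher number from compound 2 to compound 3 (0.21 log units; within the scatter)), although only the second carries a chlorine. Pyridin-4-yl in place of 6-methylpyridin-2-yl gives a large step (a 270-fold higher number from compound 1 to compound 3 (2.44 log units; beyond the scatter)), so among these three compounds, only compound 1, with 6-methylpyridin-2-yl, reaches the low nanomolar range. No measurement given here explains this difference. Still open, going by these compounds, is whether a plain pyridin-2-yl, a 6-chloropyridin-2-yl or a phenyl on the same nitrogen would match compound 1 or fall with compound 2 and compound 3.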